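Swapping the iodoacetamide tail of a nucleotide analogue measured for hexokinase-1 inhibition

The source may hold more compounds than are shown below. What is called first, only, known or untested is meant among the compounds shown, and "the series" means these compounds.

Three nucleotide analogues share a triphosphate-bearing sugar and an aromatic core, and differ in the tail that hangs from an amino nitrogen on that core. Compound 1, `O=C(CI)NCCCCCCCNc1ncnc2c1ncn2[C@@H]1O[C@H](COP(=O)(O)OP(=O)(O)OP(=O)(O)O)[C@@H](O)[C@H]1O`, carries a seven-carbon chain ending in an iodoacetamide. In an assay on isolated protein for inhibition of hexokinase-1 (Rattus norvegicus), with a stated time of 6 h, tested at 10 mM (on this read-out higher numbers stand for more inhibition at the one concentration tested (going by the name of the read-out) and lower numbers for less inhibition), compound 1 gives 20%, the highest of the three numbers. Compound 2, `O=C(CI)NCCCCCCC(=O)NCCCCCCNc1ncnc2c1ncn2[C@@H]1O[C@H](COP(=O)(O)OP(=O)(O)OP(=O)(O)O)[C@@H](O)[C@H]1O`, extends the tail through a second amide link and in this assay gives 0%, a drop beyond the scatter. Compound 3, `Nc1ncnc2c1nc(NCCNC(=O)CI)n2[C@@H]1O[C@H](COP(=O)(O)OP(=O)(O)OP(=O)(O)O)[C@@H](O)[C@H]1O`, places a short iodoacetamide-tipped chain on a different nitrogen of the core and in this assay gives 0%, likewise beyond the scatter below compound 1.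

Compound 4, `CC(=O)NCCCCCCCCNc1ncnc2c1ncn2[C@@H]1O[C@H](COP(=O)(O)OP(=O)(O)OP(=O)(O)O)[C@@H](O)[C@H]1O`, has not been measured. It differs from compound 1 in one place: acetamidomethyl in place of ((iodomethyl)carbonyl)amino on a saturated chain carbon, seven bonds along the chain from a nitrogen on an aromatic ring. The iodine is gone, and the chain is one carbon longer before its plain acetamide end. For the measured compounds named here, no measured pair shows this exact exchange, so the expectation rests only on the three numbers above, which put compound 1 alone at a modest reading and both other tails at none. For compound 4 the step of a number 15 percentage points lower from compound 1 to compound 4 (beyond the scatter) is expected, a fall to about the scatter's edge. Compound 4 is thus estimated at 5%, with a likely range from 0% to 18%.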

Compound 4, a percentage reported as inhibition, at one concentration (the size of the read-out at that concentration, not a potency): 0%
For compound 4 the middle estimate is 5 percentage points above the measured one; the range from low to high includes it.
By their numbers in this assay, from the lowest: compounds 2, 3 and 4 (each within the scatter of the next); then compound 1.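

For the compounds shown here, this is the first exchange in the set made in one place only. In this assay putting acetamidomethyl in place of ((iodomethyl)carbonyl)amino on a saturated chain carbon, seven bonds along the chain from a nitrogen on an aromatic ring, gives a number 20 percentage points lower from compound 1 to compound 4 (beyond the scatter) and so shows that the reading of compound 1 does not survive this change to the end of its tail. The two groups match in heavy atoms, hydrogen-bond donors and acceptors, and net charge, yet the exchange removes the iodine and lengthens the chain at once, and this single pair cannot separate those two changes. Nothing measured here bears on why the reading falls.

Open, as far as these compounds go, is whether the iodine or the chain length carries the difference: a plain acetamide on the chain of compound 1, or an iodoacetamide on the chain of compound 4, would each alter only one of the two. Also open, from the compounds shown here alone, is how a chloroacetamide or a bromoacetamide would read at this place.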